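The source may hold more compounds than are shown below. What is called first, only, known or untested is meant among the compounds shown, and "the series" means these compounds.

Compound 3 `CNC(=O)c1cc(N)c(Nc2ccc(C#N)cc2)cc1Oc1c(C)cc(CCC#N)cc1C` gives > 9100 nM in an ADME assay on TZM cells (Homo sapiens) for cytotoxicity, read by XTT assay, with a stated time of 4 days (a higher number here means that more compound is tolerated, a lower number that less compound is tolerated), and this is a limit, not a number. The next step leads to compound 4 `Cc1cc(CCC#N)cc(C)c1Oc1cc(Nc2ccc(C#N)cc2)c(N)cc1N`, with amino in place of methylcarbamoyl on an aromatic carbon. Among the compounds with values here, the one measured step that bears on this change is a step that the limit leaves unreadable from compound 1 to compound 3, with methylamino in place of hydroxy on a carbonyl carbon, so it offers no size to carry over. The remaining guide is the pair of numeric values in this assay. Compound 1 `Cc1cc(CCC#N)cc(C)c1Oc1cc(Nc2ccc(C#N)cc2)c(N)cc1C(=O)O` gives 14300 nM and compound 2 `CC(=O)CCc1cc(C)c(Oc2cc(Nc3ccc(C#N)cc3)c(N)cc2C(F)(F)F)c(C)c1` gives 11100 nM, and these two lie within the scatter of each other, although the groups on the shared core differ. On the values of compound 1 at 14300 nM and compound 2 at 11100 nM, no direction can be drawn, and no shift beyond the scatter is expected. The expected change is a step that the limit leaves unreadable from compound 3 to compound 4. Compound 4 is estimated at 11000 nM, with an expected range of 4000 nM to 30000 nM.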

Compound 4, half-maximal cytotoxic concentration: > 25000 nM
Compound 4: a limit, no number (the forecaster's own chance of this, stated with the estimate: 30%); at least 2.2-fold (0.35 log units) between middle value and limit.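

In this assay compound 4, which carries a single-atom amino group on this aromatic carbon, gives > 25000 nM, and this is a limit, not a number. Amino in place of carboxy gives an at least 1.7-fold higher number from compound 1 to compound 4 (0.24 log units; that floor lies within the scatter), so a gain beyond the scatter is neither shown nor ruled out, but this carbon now holds a group without a carbonyl with no drop in the number. The steps that start or end at compound 3 cannot be read.

On these data alone, the true value of compound 4 remains unknown, so the size of any effect of this change stays open. As far as these compounds go, it is also open whether a hydroxy, methoxy or dimethylamino group on this carbon would keep the number as high as the amino group does.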